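Swapping a phenyl for a hydroxymethyl at the chain end

The source may report more compounds than this note shows. Statements on the series, on what has been measured and on what is new or still open speak of the compounds shown alone.

Measured compounds:
compound 1, `[SeH]c1nc([SeH])c2cccnc2n1`: "not determined" (no result reported)
compound 2, `CSc1nc(NCCCCc2ccccc2)c2ccccc2n1`: > 100000 nM
compound 3, `C[Se]c1nc(N)c2cccnc2n1`: > 100000 nM

Of the compounds shown here, three have been tested in a functional assay on CCRF-CEM cells (Homo sapiens) for cytotoxicity, read by MTT assay, with a stated time of 72 h; a higher number here means that more compound is tolerated, a lower number that less compound is tolerated. Compound 1 has no result there, reported as "not determined" (no result reported). For compound 2 the assay gives only a limit, > 100000 nM, so no number is known. For compound 3 the result is likewise a limit, > 100000 nM. Compound 2 therefore stands at the edge of what this assay can report, alongside compound 3, and no measured step separates any pair of these compounds; what is shared is the limit of > 100000 nM in this assay, at which 2 of the 3 values shown sit.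

Compound 4, `CSc1nc(NCCCCCO)c2ccccc2n1`, has not yet been measured. Its change from compound 2 is hydroxymethyl in place of phenyl on a saturated chain carbon, four bonds along the chain from a nitrogen on an aromatic ring. No measured step of this kind exists among the compounds shown, so the expectation rests only on where compound 2 sits. The step that the limit leaves unreadable from compound 2 to compound 4 is expected to be none beyond the scatter, with compound 4 most likely remaining at the limit as well. The estimate for compound 4 in this assay is 150000 nM, with a range from 40000 nM to 600000 nM.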

Compound 4, concentration lethal to 50% of the cells: > 100000 nM
Compound 4 gave a limit, no number (the forecaster's own chance of this, stated with the estimate: 85%); the middle value is on the limit's open side.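

Within the data shown here, compound 2 and compound 4 each give only a limit in this assay, so no step between them can be read: the limit of > 100000 nM in this assay, at which 3 of the 4 values shown sit.

The compounds shown leave open whether hydroxymethyl in place of phenyl changes how much compound these cells tolerate at all.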